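Dimethylamino for Acetyl on the Pendant Phenyl Ring

The source may report more compounds than this note shows. Statements on the series, on what has been measured and on what is new or still open speak of the compounds shown alone.

Compound 1 `COc1cc(C)cc(-c2c(-c3ccnc(-c4ccc(C(C)=O)cc4)c3)cnn2CC#N)c1` was examined in a functional assay on ACHN cells (Homo sapiens) for inhibition, read by sulforhodamine B assay, with a stated time of 48 h; a higher number here means that more compound is tolerated, a lower number that less compound is tolerated. In this assay compound 1 gives > 100000 nM, which is a limit of the assay and not a number. Two related compounds accompany it. Compound 2 `Cc1cc(O)cc(-c2nn(CC#N)cc2-c2ccnc(-c3ccc(Oc4ccccc4)cc3)c2)c1` gives 33800 nM in this assay. Compound 3 `COc1cc(C)cc(-c2nn(CC#N)cc2-c2ccnc(-c3ccc(N(C)C)cc3)c2)c1` gives > 100000 nM in this assay, again only a limit. Among the compounds with values here, compound 1 therefore stands at the limit of > 100000 nM in this assay, at which 2 of the 3 values shown sit, and no step between measured compounds is available to guide the next change. The change to compound 4 `COc1cc(C)cc(-c2c(-c3ccnc(-c4ccc(N(C)C)cc4)c3)cnn2CC#N)c1` is dimethylamino in place of acetyl on an aromatic carbon. The same dimethylamino group is carried by compound 3, which also sits at the limit of > 100000 nM in this assay, at which 2 of the 3 values shown sit, but compound 3 does not share the core arrangement of compound 1, so its value can only be noted alongside. Compound 4 is expected to remain near that limit, so a number no higher from compound 1 to compound 4 (the limit leaves the size open) is estimated as none beyond the scatter. Compound 4 is estimated at 100000 nM, within 30000 nM to 300000 nM.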

Compound 4, concentration lethal to 50% of the cells: > 100000 nM
Compound 4 ended at the assay's limit (the forecaster's own chance of this, stated with the estimate: 70%); the middle value sits exactly at the limit.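

Compound 1 and compound 4 both stand at a limit of the assay and not at a number, so dimethylamino in place of acetyl gives no readable step: the limit of > 100000 nM in this assay, at which 3 of the 4 values shown sit.

The compounds shown leave open whether 4-acetylphenyl and 4-(dimethylamino)phenyl differ at all in this read-out.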